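The source may hold more compounds than are shown below. What is called first, only, known or untested is meant among the compounds shown, and "the series" means these compounds.

Compound 1 `Cn1nc(-c2nnc(-c3ccccc3)o2)c2ccccc21` is the point of reference. In an ADME assay on L02 cells (Homo sapiens) for cytotoxicity, read by MTT assay, with a stated time of 72 h (a higher number here means a weaker inhibitor, a lower number a stronger inhibitor), compound 1 gives 84600 nM. Compound 2 `COc1ccc(-c2nnc(-c3nn(C)c4ccccc34)o2)cc1` carries methoxy in place of hydrogen on an aromatic carbon, and its result is a limit of the assay: in this assay compound 2 gives > 100000 nM. Compound 3 `Cn1nc(-c2nnc(-c3ccc(O)cc3)o2)c2ccccc21` also stands at a limit of the assay, and in this assay compound 3 gives > 100000 nM. Thus (the limit of > 100000 nM in this assay, at which 2 of the 3 values shown sit). The measured steps read an at least 1.1-fold higher number from compound 1 to compound 2 (0.07 log units; that floor lies within the scatter) and an at least 1.1-fold higher number from compound 1 to compound 3 (0.07 log units; that floor lies within the scatter), while a step that the two limits leave unreadable from compound 2 to compound 3. Compound 4 `Cc1ccc(-c2nnc(-c3nn(C)c4ccccc34)o2)cc1` differs from compound 3 by methyl in place of hydroxy on an aromatic carbon. Going by the values given here, no measured step covers this change directly, and the nearest ones move within the scatter or stop at the limit. The expected shift is a step that the limit leaves unreadable from compound 3 to compound 4. Compound 4 is estimated at 150000 nM, within 60000 nM to 400000 nM.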

Compound 4, half-maximal inhibitory concentration: > 100000 nM
Compound 4: no number, only a limit; the forecaster's own chance of this, stated with the estimate: 65%; the middle value does not contradict the limit.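

With methyl, which brings no hydrogen-bond donor or acceptor, on the aromatic carbon para to a large group, the result matches those with hydroxy and methoxy there: in this assay compound 4 gives > 100000 nM, a limit of the assay. Going by these compounds alone, the one readable step is an at least 1.1-fold higher number from compound 1 to compound 4 (0.07 log units; that floor lies within the scatter), while the steps from compound 2 and from compound 3 to compound 4 cannot be read. The limit now holds most of the series: the limit of > 100000 nM in this assay, at which 3 of the 4 values shown sit.

No order among methyl, methoxy and hydroxy can be given at this position. On these data alone, whether an amine or a carboxylic acid there would give a readable value remains open.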